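The compounds below may be only part of what the source reports. "The series", "measured", "known", "first", "only" and "open" are said of these compounds alone.

Compound 3 `Cc1nc(-c2ccccc2)c(C(=O)N2CCN(c3ccccc3C(F)(F)F)CC2)o1` carries a 2-(trifluoromethyl)phenyl on an amine nitrogen in a ring of the shared core. In a functional assay on HL-60 cells (Homo sapiens) for inhibition, read by MTT assay, with a stated time of 72 h (a higher number here means a weaker inhibitor, a lower number a stronger inhibitor), compound 3 gives 120 nM, the highest of the two numbers reported; its nearest neighbour is compound 1 `Cc1nc(-c2ccccc2)c(C(=O)N2CCN(c3cccc(C)c3C)CC2)o1`, which in this assay gives 35 nM. Compound 2 `CC(=O)c1ccc(N2CCN(C(=O)c3oc(C)nc3-c3ccccc3)CC2)cc1`, with a 4-acetylphenyl at the same place, is reported in this assay as "not active" (no number reported).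

Compound 4 `Cc1nc(-c2ccccc2)c(C(=O)N2CCN(c3cc(Cl)cc(Cl)c3)CC2)o1` differs from compound 3 only at that ring nitrogen: 3,5-dichlorophenyl in place of 2-(trifluoromethyl)phenyl on an amine nitrogen in a ring.

Within the data shown here, the one measured step at this position, a 3.4-fold higher number from compound 1 to compound 3 (0.54 log units; beyond the scatter), is a modest change, and compound 2 shows that a further variation there can remove activity altogether. Among the measured compounds shown here, no measured pair exchanges a 2-(trifluoromethyl)phenyl for a 3,5-dichlorophenyl, so the direction is uncertain; a modest step, either way, is the expectation. Compound 4 is therefore expected to lie near compound 3 in this assay, at an estimated 150 nM with a range from 40 nM to 600 nM, which means an expected step of a 1.3-fold higher number from compound 3 to compound 4 (0.10 log units; within the scatter).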

Compound 4, half-maximal inhibitory concentration: 41.8 nM
Beside the measured number, compound 4's estimate is 3.6-fold (0.55 log units) above it, within the range that was stated.
By their numbers in this assay, from the lowest: compounds 1 and 4 (each within the scatter of the next); then compound 3.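

In this assay the exchange of 2-(trifluoromethyl)phenyl for 3,5-dichlorophenyl on the ring nitrogen gives a 2.9-fold lower number from compound 3 to compound 4 (0.46 log units; beyond the scatter) and so shows that this position responds to a change of substituents on the phenyl even when the step stays modest. The other new comparison, a 1.2-fold higher number from compound 1 to compound 4 (0.08 log units; within the scatter) with 3,5-dichlorophenyl in place of 2,3-dimethylphenyl, shows that two differently substituted phenyl groups can give numbers that cannot be told apart here, with compound 3 the higher of the three. The data shown offer no measurement that explains these differences.

As far as these compounds go, it remains open whether a phenyl group is needed on this nitrogen at all, or whether a pyridine or a benzyl group would serve there. From the compounds shown here alone, it is also open whether a nitrile or an amide on the phenyl would, like the 4-acetylphenyl of compound 2, remove activity.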